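Replacing cyclohexyl with oxolan-3-yl on the side chain

This account rests on a few compounds, and the source may have more. Where it says the series, first, only, none or still open, it means among the compounds named here.

Measured in a functional assay on MV4-11 cells (Homo sapiens) for antiproliferative activity, read by CellTiter-Glo, with a stated time of 72 h; on this read-out lower numbers stand for stronger inhibition of growth and higher numbers for weaker inhibition of growth:
- compound 1 `COCCN[C@H]1CC[C@H](Nc2cc(-c3csc(OCC4CCOCC4)n3)c(Cl)cn2)CC1`: 570 nM
- compound 2 `COCCN[C@H]1CC[C@H](Nc2cc(-c3csc(NCC4CC4)n3)c(Cl)cn2)CC1`: 740 nM
- compound 3 `COCCN[C@H]1CC[C@H](Nc2cc(-c3csc(NCC4CCCCC4)n3)c(Cl)cn2)CC1`: 820 nM

Compound 3, at 820 nM, has the highest of these numbers, but it stands within the scatter of the other two, as a 1.1-fold higher number from compound 2 to compound 3 (0.04 log units; within the scatter) and a 1.4-fold higher number from compound 1 to compound 3 (0.16 log units; within the scatter) show.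

Compound 4 `COCCN[C@H]1CC[C@H](Nc2cc(-c3csc(NCC4CCOC4)n3)c(Cl)cn2)CC1` has no value yet. It differs from compound 3 at one place: oxolan-3-yl in place of cyclohexyl on a saturated chain carbon bound to a nitrogen on an aromatic ring. Going by the values given here, the closest precedent is the change at this same place, cyclohexyl in place of cyclopropyl, which gave a 1.1-fold higher number from compound 2 to compound 3 (0.04 log units; within the scatter). Compound 1 carries (oxan-4-yl)methoxy instead, and its steps were also small: a 1.3-fold higher number from compound 1 to compound 2 (0.11 log units; within the scatter) and a 1.4-fold higher number from compound 1 to compound 3 (0.16 log units; within the scatter). Among the compounds with values here, none of the three compounds leaves the scatter, so no step beyond it is expected in this assay, although no measured compound carries oxolan-3-yl. The expected change is a 1.2-fold lower number from compound 3 to compound 4 (0.07 log units; within the scatter). For compound 4 the estimated value is 700 nM, with an expected range of 350 nM to 1400 nM.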

Compound 4, concentration for 50% growth inhibition: 493 nM
Compound 4: the middle estimate sits 1.4-fold (0.15 log units) above what was measured; the measured number falls inside the stated range.
By their numbers in this assay, from the lowest: compounds 4, 1, 2 and 3 (each within the scatter of the next).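

In this assay, going by these compounds alone, oxolan-3-yl, the first group at this place to carry a ring oxygen, gives a 1.7-fold lower number from compound 3 to compound 4 (0.22 log units; within the scatter) and a 1.5-fold lower number from compound 2 to compound 4 (0.18 log units; within the scatter). A ring with a hetero atom on a saturated chain carbon bound to a nitrogen on an aromatic ring therefore stays within the scatter of the carbon-only rings, cyclohexyl and cyclopropyl. The change from (oxan-4-yl)methoxy to ((oxolan-3-yl)methyl)amino gives a 1.2-fold lower number from compound 1 to compound 4 (0.06 log units; within the scatter), so all four compounds now lie within the scatter of their neighbours, and nothing shown accounts for these small differences.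

The compounds shown leave open whether any group at this place would produce a step beyond the scatter, such as a carboxylic acid, a piperidine ring or a longer chain. They also leave open whether the oxygen itself matters, which a comparison of oxolan-3-yl with cyclopentyl could address.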